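This account rests on a few compounds, and the source may have more. Where it says the series, first, only, none or still open, it means among the compounds named here.

Working notes on the series. Compound 1 `CCOC(=O)c1sc(-c2cccc(NC(=O)c3ccc(Cl)cc3)c2)nc1Nc1ccc(N2CCN(C)CC2)cc1` gives "not determined" (no result reported) in a functional assay on Ramos cells (Homo sapiens) for antiproliferative activity, read by CCK-8 assay, with a stated time of 72 h; a higher number here means a weaker inhibitor, a lower number a stronger inhibitor. Compound 2 `CN1CCN(c2ccc(Nc3nc(-c4cccc(NC(=O)c5ccc(C(F)(F)F)cc5)c4)sc3C(N)=O)cc2)CC1` gives 1580 nM. Within the data shown here, compound 3 `CN1CCN(c2ccc(Nc3nc(-c4cccc(NC(=O)c5ccc(C(C)(C)C)cc5)c4)sc3C(N)=O)cc2)CC1` gives 8600 nM, the higher of the two numbers available in this assay; the step of a 5.4-fold higher number from compound 2 to compound 3 (0.74 log units; beyond the scatter) is the only measured change at this position. Compound 4 `CN1CCN(c2ccc(Nc3nc(-c4cccc(NC(=O)c5ccc(Cl)cc5)c4)sc3C(N)=O)cc2)CC1` differs from compound 3 by chloro in place of tert-butyl on an aromatic carbon. Compound 1 carries the same chloro group on the same ring but supplies no number to compare. Among the measured compounds shown here, the single step that bears on this change, from compound 2 to compound 3, was modest, and compound 4 carries neither of those two groups, so the expectation for compound 4 is a drop in number back toward that of compound 2, of no more than the size of that step: a 3.1-fold lower number from compound 3 to compound 4 (0.49 log units; beyond the scatter). The estimate for compound 4 in this assay is 2800 nM, with a range from 900 nM to 9000 nM.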

Compound 4, half-maximal inhibitory concentration: 1360 nM
For compound 4 the middle estimate is 2.1-fold (0.31 log units) above the measured one; the range from low to high includes it.
By their numbers in this assay, from the lowest: compounds 4 and 2 (each within the scatter of the next); then compound 3.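

In this assay, chloro in place of tert-butyl on this aromatic carbon gives a 6.3-fold lower number from compound 3 to compound 4 (0.80 log units; beyond the scatter), so tert-butyl now stands apart from both other groups at this position, each by a step beyond the scatter. Chloro in place of trifluoromethyl gives a 1.2-fold lower number from compound 2 to compound 4 (0.07 log units; within the scatter), so these two groups cannot be told apart here. As far as these compounds go, how an amine or a carboxylic acid on this carbon would compare with chloro remains open. No measurement at hand accounts for the steps at this position.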